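From thiophen-2-yl to 2-chlorophenyl on a shared core

The source may report more compounds than this note shows. Statements on the series, on what has been measured and on what is new or still open speak of the compounds shown alone.

In a functional assay on microsomes for inhibition, with a stated time of 1 h (on this read-out lower numbers stand for stronger inhibition and higher numbers for weaker inhibition), compound 2 `CCOC(=O)c1cnn(-c2nc(-c3cccs3)c(C#N)c(=O)n2C)c1N` gives 97 ug/mL, and compound 1 `CCOC(=O)c1cnn(-c2nc(-c3ccccc3O)c(C#N)c(=O)n2C)c1N` gives 57 ug/mL. Going by the values given here, these are the only two numbers so far, and they lie within the scatter of each other, so neither compound can be ranked above the other.

Compound 3 `CCOC(=O)c1cnn(-c2nc(-c3ccccc3Cl)c(C#N)c(=O)n2C)c1N` carries 2-chlorophenyl in place of thiophen-2-yl on an aromatic carbon. Among the compounds with values here, the only measured step at this place, thiophen-2-yl in place of 2-hydroxyphenyl, was a 1.7-fold higher number from compound 1 to compound 2 (0.23 log units; within the scatter), so no step beyond the scatter is expected in this assay. A single step is a thin guide, and the range is kept wide for that reason. The expected step is a 1.3-fold lower number from compound 2 to compound 3 (0.11 log units; within the scatter). The estimate for compound 3 is 75 ug/mL, with an expected range from 35 ug/mL to 160 ug/mL.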

Compound 3, half-maximal inhibitory concentration: 102 ug/mL
For compound 3 the middle estimate is 1.4-fold (0.13 log units) below the measured one; low and high end bracket the measured number.
By their numbers in this assay, from the lowest: compounds 1, 2 and 3 (each within the scatter of the next).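

In this assay, putting 2-chlorophenyl in place of thiophen-2-yl gives a 1.1-fold higher number from compound 2 to compound 3 (0.02 log units; within the scatter), so a five-membered aromatic ring with a hetero atom and a six-membered aromatic ring of carbon only cannot be told apart at this position. Chloro in place of hydroxy on the phenyl ring gives a 1.8-fold higher number from compound 1 to compound 3 (0.25 log units; within the scatter), which shows that this exchange also stays inside the scatter and that all three compounds read alike in this assay. There is no further evidence on what lies behind this result.

On these data alone, all three groups at this position are aromatic rings, so it remains open whether an amine, a carboxylic acid or a longer alkyl chain placed here would move the number beyond the scatter. As far as these compounds go, it is also open whether plain phenyl, with neither chloro nor hydroxy, would read any differently.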